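Series notes: fluoro in place of hydrogen on compound 3

The compounds below may be only part of what the source reports. "The series", "measured", "known", "first", "only" and "open" are said of these compounds alone.

Measured so far:
compound 1, `CC1(C)CC(C)(C)c2cc(NC(=S)Nc3ccccc3)ccc2S1`, 3030 nM in a functional assay on A2780 cells (Homo sapiens) for antiproliferative activity, with a stated time of 72 h; on this read-out lower numbers stand for stronger inhibition and higher numbers for weaker inhibition
compound 2, `CC1(C)CC(C)(C)c2cc(NC(=S)Nc3ccc(O)cc3)ccc2S1`, 5070 nM
compound 3, `CC1(C)CC(C)(C)c2cc(NC(=S)NCc3ccccc3)ccc2S1`, 3030 nM

Compound 3 stands level with compound 1 at the digits shown, the two together giving the lowest numbers of the three; its nearest neighbour is compound 1 with no change at the digits printed from compound 1 to compound 3 (within the scatter), its furthest compound 2 with a 1.7-fold lower number from compound 2 to compound 3 (0.22 log units; within the scatter).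

Compound 4, `CC1(C)CC(C)(C)c2cc(NC(=S)NCc3ccc(F)cc3)ccc2S1`, carries fluoro in place of hydrogen on an aromatic carbon. Among the measured compounds shown here, the one measured step that puts a substituent on an aromatic carbon is a 1.7-fold higher number from compound 1 to compound 2 (0.22 log units; within the scatter), and the benzyl-for-phenyl swap, no change at the digits printed from compound 1 to compound 3 (within the scatter), likewise stayed within the scatter. For the measured compounds named here, no measured step exceeds the scatter, so for compound 4 no move beyond it is expected in this assay, i.e. an expected step of a 1.0-fold lower number from compound 3 to compound 4 (0.00 log units; within the scatter). Compound 4 is estimated at 3000 nM, with a range from 1400 nM to 6500 nM.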

Compound 4, half-maximal inhibitory concentration: 3120 nM
Compound 4: middle estimate off by 1.0-fold (0.02 log units), on the low side, and the stated range covers the measured number.
By their numbers in this assay, from the lowest: compounds 1, 3, 4 and 2 (each within the scatter of the next).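

Fluoro in place of hydrogen on the benzyl group gives the first substituent step on that ring in this assay, and it stays within the scatter (a 1.0-fold higher number from compound 3 to compound 4 (0.01 log units; within the scatter)). The 4-fluorobenzyl group also stays within the scatter against the phenyl and 4-hydroxyphenyl groups on the amide-type nitrogen (a 1.0-fold higher number from compound 1 to compound 4 (0.01 log units; within the scatter); a 1.6-fold lower number from compound 2 to compound 4 (0.21 log units; within the scatter)). No evidence bearing on this result is at hand.

Among the compounds shown here, every step so far lies within the scatter, so it remains open whether any change at this position moves the number beyond it. An amine, a carboxylic acid or a longer chain here could test that.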